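Methoxy for trifluoromethyl in a weakly active series

The source may report more compounds than this note shows. Statements on the series, on what has been measured and on what is new or still open speak of the compounds shown alone.

Going by the values given here, compound 2 `COc1ccc(C2=NN(c3ccc(-c4ccccc4)nn3)C(c3ccc(C(F)(F)F)cc3)C2)cc1` holds the only numerical reading so far: in a functional assay on Caco-2 cells (Homo sapiens) for antiproliferative activity, read by MTT assay, with a stated time of 24 h (a lower number here means a stronger inhibitor, a higher number a weaker inhibitor), compound 2 gives 65000 nM. Compound 1 `COc1ccc(C2=NN(c3ccc(-c4ccccc4)nn3)C(c3ccc(Cl)cc3)C2)cc1` carries a chloro where compound 2 carries a trifluoromethyl. In this assay compound 1 gives > 100000 nM, which is a limit of the assay and not a number. The step with trifluoromethyl in place of chloro on an aromatic carbon, an at least 1.5-fold lower number from compound 1 to compound 2 (0.18 log units; that floor lies within the scatter), is therefore only a floor, and the limit of > 100000 nM in this assay, at which 1 of the 2 values shown sits, marks where compound 1 sits.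

Compound 3 `COc1ccc(C2=NN(c3ccc(-c4ccccc4)nn3)C(c3ccc(OC)cc3)C2)cc1` is the next variant: methoxy in place of trifluoromethyl on an aromatic carbon. Among the compounds with values here, no measured step covers a methoxy at this place; the one step available, an at least 1.5-fold lower number from compound 1 to compound 2 (0.18 log units; that floor lies within the scatter), exchanged two groups at the same aromatic carbon and reached only its floor, inside the scatter. On that basis the change is expected to move this assay by a 1.2-fold higher number from compound 2 to compound 3 (0.09 log units; within the scatter), no step beyond the scatter in either direction. Compound 3 is thus expected to read 80000 nM in this assay, between 30000 nM and 200000 nM, with a real chance that only a limit is returned.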

Compound 3, half-maximal inhibitory concentration: > 100000 nM
Compound 3 was reported as a limit (the forecaster's own chance of this, stated with the estimate: 40%); middle value at least 1.2-fold (0.09 log units) away from the limit.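

In this assay compound 3 gives > 100000 nM, which is a limit of the assay and not a number. The step with methoxy in place of trifluoromethyl on this aromatic carbon, an at least 1.5-fold higher number from compound 2 to compound 3 (0.18 log units; that floor lies within the scatter), is therefore a floor only, as was an at least 1.5-fold lower number from compound 1 to compound 2 (0.18 log units; that floor lies within the scatter), so the change from 4-(trifluoromethyl)phenyl to 4-methoxyphenyl gives no measured size. Chloro and methoxy at this position now both end in a limit, compound 2 remains the only compound with a numerical reading, and the step between the two limit compounds cannot be read: the limit of > 100000 nM in this assay, at which 2 of the 3 values shown sit.

On these data alone, whether trifluoromethyl truly separates from chloro and methoxy at this position stays open, as both readable steps reach only floors that lie inside the scatter. Also open, as far as these compounds go, is how an amine, a carboxylic acid or a longer chain on this aromatic carbon would read in this assay, and whether any group here gives a reading well clear of the limit.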